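Benzyl ethers on the shared core: expectation for compound 4

A few compounds are considered here, and "the series" means these few. Any claim that something is new, unique, unknown or untested is made for them only; others in the source may bear on it.

The shared core carries an ether on an aromatic ring, and the three measured compounds differ only in what sits on that oxygen. Compound 1 `C#CCOc1ccc2c(=O)c(-c3cc(OC)c(OC)cc3OC)coc2c1` bears a propargyl group and in a functional assay on HepG2 cells (Homo sapiens) for antiproliferative activity, read by MTT assay, with a stated time of 24 h (a higher number here means a weaker inhibitor, a lower number a stronger inhibitor), gives 4950 nM. Compound 2 `COc1cccc(C(=O)Oc2ccc3c(=O)c(-c4cc(OC)c(OC)cc4OC)coc3c2)c1` carries a (3-methoxyphenyl)carbonyl there; in this assay compound 2 reaches only a limit, > 10000 nM, as the limit of > 10000 nM in this assay, at which 1 of the 3 values shown sits, records. Compound 3 `COc1cc(OC)c(-c2coc3cc(OCc4ccccc4C)ccc3c2=O)cc1OC` carries a 2-methylbenzyl; in this assay compound 3 gives 1860 nM. Of the two numbers, compound 1 stands highest, with compound 3 nearest: a 2.7-fold lower number from compound 1 to compound 3 (0.43 log units; beyond the scatter). The step of an at least 2.0-fold higher number from compound 1 to compound 2 (0.30 log units; that floor lies within the scatter) rests on a limit and cannot be separated from the scatter.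

Compound 4 `COc1cc(OC)c(-c2coc3cc(OCc4ccccc4Br)ccc3c2=O)cc1OC` is not yet measured in this assay; it differs from compound 1 by 2-bromophenyl in place of ethynyl on a saturated chain carbon bound to an oxygen on an aromatic ring. The step bearing most directly on it is a 2.7-fold lower number from compound 1 to compound 3 (0.43 log units; beyond the scatter), where a benzyl ether likewise replaces the propargyl ether; an at least 5.3-fold lower number from compound 2 to compound 3 (0.73 log units; beyond the scatter) also places the benzyl ether at the lower end. A modest downward step is therefore expected, a 2.5-fold lower number from compound 1 to compound 4 (0.39 log units; beyond the scatter). The estimated value for compound 4 is 2000 nM, with a range from 800 nM to 5000 nM.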

Compound 4, half-maximal inhibitory concentration: 2180 nM
Beside the measured number, compound 4's estimate is 1.1-fold (0.04 log units) below it; low and high end bracket the measured number.
By their numbers in this assay, from the lowest: compounds 3 and 4 (each within the scatter of the next); then compound 1. At a limit, above all of these: compound 2.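

In this assay, the 2-bromobenzyl of compound 4 repeats the downward step seen with the 2-methylbenzyl, a 2.3-fold lower number from compound 1 to compound 4 (0.36 log units; beyond the scatter), so two benzyl ethers now stand below the propargyl ether rather than one. On the aromatic carbon, bromo in place of methyl gives a 1.2-fold higher number from compound 3 to compound 4 (0.07 log units; within the scatter), so the two substituents cannot be told apart in this assay. The (3-methoxyphenyl)carbonyl group remains separate, an at least 4.5-fold lower number from compound 2 to compound 4 (0.66 log units; beyond the scatter), but this step is only a floor, since compound 2 sits at a limit: the limit of > 10000 nM in this assay, at which 1 of the 4 values shown sits.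

From the compounds shown here alone, whether the lower numbers need any substituent on the benzyl ring remains open, as does the effect of an amine or a carboxylic acid on that ring. The values also give no cause for the step from propargyl to benzyl.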